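Fluoro to chloro on the pendant phenyl ring

The source may hold more compounds than are shown below. What is called first, only, known or untested is meant among the compounds shown, and "the series" means these compounds.

Compound 1, `Clc1ccc(-c2ccc3nc(-c4ccccc4)cn3c2)cc1`, in an assay for inhibition of Retinaldehyde dehydrogenase 3 (Homo sapiens), with a stated time of 5 min (on this read-out higher numbers stand for weaker inhibition and lower numbers for stronger inhibition), gives 45800 nM.
Compound 2, `COc1cccc(-c2cn3cc(-c4ccc(F)cc4)ccc3n2)c1`, in this assay gives 21200 nM.

Of the two measured compounds, compound 2 shows the lower number, and its gap to compound 1 lies beyond the usual scatter of repeated measurements. The next compound, compound 3, `COc1cccc(-c2cn3cc(-c4ccc(Cl)cc4)ccc3n2)c1`, is not yet measured. It differs from compound 2 in one place: chloro in place of fluoro on an aromatic carbon. For the measured compounds named here, no measured pair shows this same swap on its own, so no step size can be read off directly; compound 1 also carries a chloro group, but it differs from compound 2 in a second place too, and the two values show only that compound 1 sits higher than compound 2. A halogen swap of this kind is expected to shift the number little, if at all, beyond the scatter, leaning slightly toward a lower value. The step from compound 2 to compound 3 is expected to be a 1.2-fold lower number from compound 2 to compound 3 (0.10 log units; within the scatter). Compound 3 is therefore estimated at 17000 nM, within a range from 7000 nM to 45000 nM.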

Compound 3, half-maximal inhibitory concentration: 6400 nM
The estimate for compound 3 lay 2.7-fold (0.42 log units) above the measured number; measured number below the stated range.
By their numbers in this assay, from the lowest: compound 3; then compound 2; then compound 1.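

In this assay, going from 4-fluorophenyl to 4-chlorophenyl gives a 3.3-fold lower number from compound 2 to compound 3 (0.52 log units; beyond the scatter) and so points to stronger inhibition. For the compounds shown here, this shows that the choice of halogen at this place matters, which no earlier pair could show on its own. With the chloro group held constant, methoxy in place of hydrogen on an aromatic carbon gives a 7.2-fold lower number from compound 1 to compound 3 (0.85 log units; beyond the scatter) as a second step, whereas compound 1 and compound 2 differ in two places and could not separate the effect of the methoxy group. No measurement here explains why either change moves the number as it does. As far as these compounds go, it remains open whether a bromo or a methyl group at the same place would lower the number further than chloro. From the compounds shown here alone, it is also open whether adding the methoxy group gives a similar step when the pendant ring carries fluoro.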